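The source may report more compounds than this note shows. Statements on the series, on what has been measured and on what is new or still open speak of the compounds shown alone.

Measured in a functional assay on HT-29 cells (Homo sapiens) for antiproliferative activity, read by MTT assay, with a stated time of 72 h; on this read-out higher numbers stand for weaker inhibition and lower numbers for stronger inhibition:
Compound 1 `COc1cc(-c2nccn2CC(C)C)cc(OC)c1OC`: > 100000 nM
Compound 2 `COc1cc(-c2nccn2-c2ccc3cc[nH]c3c2)cc(OC)c1OC`: 3600 nM

Compound 1 has no measured number and stands at the limit of > 100000 nM in this assay, at which 1 of the 2 values shown sits. Compound 1 reads > 100000 nM and this is a limit. Compound 3 `COc1cccc(-n2ccnc2-c2cc(OC)c(OC)c(OC)c2)c1` has 3-methoxyphenyl in place of isobutyl on an aromatic nitrogen. Compound 2 also lacks isobutyl and reads 3600 nM, so a large move towards stronger inhibition is expected in this assay. The expected size of this move is an at least 16-fold lower number from compound 1 to compound 3 (1.22 log units; beyond the scatter), though the limit leaves it uncertain. For compound 3 the estimate is 6000 nM, with an expected range of 800 nM to 45000 nM.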

Compound 3, half-maximal inhibitory concentration: 18900 nM
Compound 3: middle estimate off by 3.2-fold (0.50 log units), on the low side, and the stated range covers the measured number.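

On the aromatic nitrogen of the shared core, 3-methoxyphenyl in place of isobutyl brings the read-out in this assay to a measurable number, with an at least 5.2-fold lower number from compound 1 to compound 3 (0.72 log units; beyond the scatter). Compound 1 stands at a limit, so this step gives only a minimum for the change: the limit of > 100000 nM in this assay, at which 1 of the 3 values shown sits.

The compounds shown leave open how much of the step belongs to the six-membered aromatic ring and how much to its methoxy group. They also leave open whether a hydroxyl or an amine in place of that methoxy, or a longer chain in place of isobutyl, would read differently.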